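Ethoxycarbonyl in place of acetyl on a chalcone-bearing coumarin

This account rests on a few compounds, and the source may have more. Where it says the series, first, only, none or still open, it means among the compounds named here.

Measured compounds:
- compound 1, `CCC(C)c1cc(/C=C/C(=O)c2ccc(Cl)cc2)cc2cc(C(C)=O)c(=O)oc12`: "not active" (no number reported) in a functional assay on KB cells (Homo sapiens) for cytotoxicity, read by sulforhodamine B assay, with a stated time of 48 h; on this read-out higher numbers stand for weaker inhibition and lower numbers for stronger inhibition
- compound 2, `CCOC(=O)c1cc2cc(C=O)cc(C(C)CC)c2oc1=O`: 132000 nM in this assay

Compound 1 stands without a number in this assay; it is reported only as inactive, so it cannot be placed on the scale on which compound 2 gives 132000 nM. Compound 3, `CCOC(=O)c1cc2cc(/C=C/C(=O)c3ccc(Cl)cc3)cc(C(C)CC)c2oc1=O`, carries the same chalcone-bearing core as compound 1 and differs from it by a single change: ethoxy in place of methyl on a carbonyl carbon. Within the data shown here, compound 2 shares this ethoxycarbonyl group with compound 3 but carries an aldehyde where compound 3 carries the chalcone arm, so no direct step is available. With compound 1 inactive and compound 2 only weakly active, the account expects compound 3 to be weak at best, with a real chance that it too is reported only as inactive. Compound 3 is estimated at 100000 nM, within a range from 20000 nM to 500000 nM.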

Compound 3, half-maximal inhibitory concentration: 14300 nM
The estimate for compound 3 lay 7.0-fold (0.84 log units) above the measured number; measured number outside the range, below it.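

Among these compounds, compound 1 carries no number in this assay, and no step from it to compound 3 can be read. How far acetyl to ethoxycarbonyl shifts activity on this shared core stays open, and nothing shown accounts for the measured activity of compound 3.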